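The source may hold more compounds than are shown below. What is called first, only, known or untested is meant among the compounds shown, and "the series" means these compounds.

Measured so far:
compound 1, `C=C1[C@](C)(O)CC[C@@]1(C)c1ccc(C)c(O)c1` — > 10 ug/mL
compound 2, `C=C1[C@](C)(O)CC[C@@]1(C)c1ccc(C)cc1` — > 10 ug/mL

In a functional assay on A549 cells (Homo sapiens) for cytotoxicity, read by MTT assay (a lower number here means a stronger inhibitor, a higher number a weaker inhibitor), compound 1 gives > 10 ug/mL, which is a limit of the assay and not a number. Compound 2 gives > 10 ug/mL, likewise a limit. Going by the values given here, the only step connecting them, a step that the two limits leave unreadable from compound 1 to compound 2, is therefore unreadable in size and direction. Among the compounds with values here, compound 2 stands at the same limit as the one other value shown; the whole set rests on (the limit of > 10 ug/mL in this assay, at which 2 of the 2 values shown sit), and no compound has yet been placed against another.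

Compound 3, `C=C1[C@](C)(O)CC[C@@]1(C)c1ccc(C)cc1O`, differs from compound 2 by hydroxy in place of hydrogen on an aromatic carbon. Within the data shown here, no readable step bears on this change; the single step available is unreadable and concerns a hydroxy at a different place. The step that the limit leaves unreadable from compound 2 to compound 3 is accordingly expected to be none beyond the scatter. Compound 3 is expected to give about 20 ug/mL, within 8 ug/mL to 60 ug/mL, most probably reported as a limit again.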

Compound 3, half-maximal inhibitory concentration: > 10 ug/mL
Compound 3: only a limit was reported (the forecaster's own chance of this, stated with the estimate: 85%); the middle value does not contradict the limit.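

Going by these compounds alone, compound 3 gives > 10 ug/mL in this assay, a limit of the assay and not a number, so no step from compound 2 to compound 3 can be read. Still open is whether a hydroxy at either aromatic place, as in compound 1 or compound 3, changes the read-out at all, the whole set resting on: the limit of > 10 ug/mL in this assay, at which 3 of the 3 values shown sit.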